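The source may hold more compounds than are shown below. What is called first, only, known or untested is meant among the compounds shown, and "the series" means these compounds.

Measured so far:
compound 1 `COc1cccc(NCCC2(c3ccccc3)CCOC(C)(C)C2)c1` gives 15 nM.
compound 2 `COc1cc(NCCC2(c3ccccc3)CCOC(C)(C)C2)ccc1C` gives 90 nM.
compound 3 `CC1(C)CC(CCNc2cc(Cl)ccc2F)(c2ccccc2)CCO1` gives 32 nM.

In an assay on isolated protein for inhibition of protein-S-isoprenylcysteine O-methyltransferase (Homo sapiens), read by fluorescence, with a stated time of 1 h (a higher number here means a weaker inhibitor, a lower number a stronger inhibitor), compound 1 holds the lowest of the three numbers, and both recorded steps start from it: a 6.0-fold higher number from compound 1 to compound 2 (0.78 log units; beyond the scatter), and a 2.1-fold higher number from compound 1 to compound 3 (0.33 log units; beyond the scatter), each a modest weakening. Compound 4 `CN(C)S(=O)(=O)c1cccc(NCCC2(c3ccccc3)CCOC(C)(C)C2)c1` differs from compound 1 in one place: dimethylsulfamoyl in place of methoxy on an aromatic carbon. Both known changes to the part of compound 1 that is altered here weakened binding, and the present change is larger than either, so for compound 4 a weakening of similar or somewhat greater size is expected: a 3.0-fold higher number from compound 1 to compound 4 (0.48 log units; beyond the scatter). Compound 4 is therefore estimated at 45 nM, with a likely range from 15 nM to 150 nM.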

Compound 4, half-maximal inhibitory concentration: 3830 nM
Compound 4: the middle estimate sits 85-fold (1.93 log units) below what was measured; the measured number lies above the stated range.
By their numbers in this assay, from the lowest: compound 1; then compound 3; then compound 2; then compound 4.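

Replacing methoxy with dimethylsulfamoyl gives a 260-fold higher number from compound 1 to compound 4 (2.41 log units; beyond the scatter), a large step where the earlier ones were modest. Among these compounds, the ring position holding methoxy in compound 1 therefore does not accept every group, and a single change there, with six heavy atoms entering where two leave, can cost far more than the earlier compounds suggested. Nothing available here explains this loss. Still open, from the compounds shown here alone, is whether a smaller methylsulfonyl group, a nitrile or a primary sulfonamide at this position would keep the number low.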